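A few compounds are considered here, and "the series" means these few. Any claim that something is new, unique, unknown or untested is made for them only; others in the source may bear on it.

Measured compounds:
- compound 1, `Cc1cn(Cc2ccc(Cl)cc2Cl)c2c(-c3nnc(NS(=O)(=O)c4cc(Cl)c(Cl)s4)o3)cc(F)cc12`: 10 nM
- compound 2, `Cc1cn(Cc2ccc(Cl)cc2Cl)c2c(-c3cc(NS(=O)(=O)c4cc(Cl)c(Cl)s4)no3)cc(F)cc12`: 5 nM

Both compounds were tested in an assay on isolated protein for displacement of a labelled ligand from prostaglandin E2 receptor EP3 subtype (Homo sapiens); on this read-out higher numbers stand for weaker inhibition and lower numbers for stronger inhibition. Compound 1 gives 10 nM, which is the higher of the two numbers. Compound 2 gives 5 nM, and the gap between compound 1 and compound 2 lies within the scatter of repeated measurements, so nothing can be said about their order.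

The next compound, compound 3 `Cc1cn(Cc2ccc(Cl)cc2Cl)c2c(-c3nnc(NS(=O)(=O)c4ccc(F)c(F)c4)o3)cc(F)cc12`, has not yet been measured. It differs from compound 1 in one place: 3,4-difluorophenyl in place of 4,5-dichlorothiophen-2-yl on a sulfonyl sulfur. No pair of measured compounds that differ in this way is available, so the size of the step cannot be read from the data shown.

An expectation for compound 3 therefore rests on the structural change alone. The step from compound 1 to compound 3 is estimated as a 3.0-fold higher number from compound 1 to compound 3 (0.48 log units; beyond the scatter), a moderate move toward weaker inhibition that may well still fall within the scatter. Compound 3 is expected to give 30 nM, with a range from 8 nM to 120 nM.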

Compound 3, half-maximal inhibitory concentration: 20 nM
The estimate for compound 3 lay 1.5-fold (0.18 log units) above the measured number; measured number inside the range.
By their numbers in this assay, from the lowest: compounds 2, 1 and 3 (each within the scatter of the next, the first and the last beyond it).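

Up to this point, the sulfonyl sulfur had carried only 4,5-dichlorothiophen-2-yl, so the data said nothing about how this assay responds to a different group there. The replacement with 3,4-difluorophenyl gives a 2.0-fold higher number from compound 1 to compound 3 (0.30 log units; within the scatter) and shows that a six-membered aromatic ring of carbon only, bearing two fluorines, can stand in for the five-membered chlorinated ring with sulfur without a change that can be told apart from the scatter, at least with the rest of compound 1 held fixed. Nothing available offers an account of why the two groups read so closely.

What the compounds shown leave open is whether this exchange would read the same on the core of compound 2, since one pair on one core cannot establish that. They also leave open how much of the aryl group the sulfonyl sulfur needs, as an unsubstituted phenyl, a single chlorine or fluorine on the ring, a carboxylic acid or an amine on the ring, or a simple methyl in place of the ring could each give a different reading.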